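A few compounds are considered here, and "the series" means these few. Any claim that something is new, unique, unknown or untested is made for them only; others in the source may bear on it.

Of the compounds shown here, two of one series have been measured in a functional assay on HepG2 cells (Homo sapiens) for antiproliferative activity, read by sulforhodamine B assay, with a stated time of 48 h, tested at 12.5 uM; a lower number here means a weaker effect, a higher number a stronger effect of the compound at the concentration tested. Compound 1 `CC(=O)Nc1c(C#N)c(-c2ccccc2)cn1-c1ccc(S(=O)(=O)Nc2ccccn2)cc1` gives 53.5% in this assay, while compound 2 `N#Cc1c(-c2ccccc2)cn(-c2ccc(S(=O)(=O)Nc3nccs3)cc2)c1NC(=O)CCC(=O)O` gives 39.6%, the lower of the two numbers and a gap to compound 1 that lies beyond the usual scatter. Going by the values given here, compound 1 and compound 2 differ from each other in more than one place, so their values show only that compound 1 is the more active of the pair at this concentration.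

The step now followed leads from compound 2 to compound 3 `N#Cc1c(-c2ccccc2)cn(-c2ccc(S(=O)(=O)Nc3ccccn3)cc2)c1NC(=O)CCC(=O)O`. Its structural change is pyridin-2-yl in place of 1,3-thiazol-2-yl on a sulfonamide nitrogen. Among the compounds with values here, no single-point step between measured compounds is available to anchor the size of this change, so the expectation is drawn from compound 1, which also carries pyridin-2-yl on its sulfonamide nitrogen and gives 53.5%. From this, the step of a number 6.4 percentage points higher from compound 2 to compound 3 (within the scatter) is expected to be a modest rise, not far beyond the scatter. Compound 3 is therefore estimated at 46%, within a range from 30% to 62%.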

Compound 3, a percentage reported as activity, at one concentration (the size of the read-out at that concentration, not a potency): 60.3%
For compound 3 the middle estimate is 14.3 percentage points below the measured one; the measured number falls inside the stated range.
By their numbers in this assay, from the lowest: compound 2; then compounds 1 and 3 (each within the scatter of the next).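

In this assay, the sulfonamide nitrogen now has its first comparison in which only one place differs: pyridin-2-yl in place of 1,3-thiazol-2-yl gives a number 20.7 percentage points higher from compound 2 to compound 3 (beyond the scatter), so the ring on this nitrogen alters the read-out when the rest of the molecule is held constant. The second comparison concerns the other end of the molecule: carboxymethyl in place of hydrogen on a saturated chain carbon bound to a carbonyl carbon gives a number 6.8 percentage points higher from compound 1 to compound 3 (within the scatter), so this change does not separate the two compounds at the concentration tested. Nothing shown accounts for either step.

The compounds shown leave open whether a pyrimidin-2-yl or a plain phenyl group on the sulfonamide nitrogen would fit this comparison. They also leave open how an amine or a longer chain would read in place of the carboxymethyl group.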